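Swapping a Thiophene Arm for Cyclohexyl on a Weak Scaffold

A few compounds are considered here, and "the series" means these few. Any claim that something is new, unique, unknown or untested is made for them only; others in the source may bear on it.

Measured compounds:
compound 1, `CCCSc1nc(Cl)c2c(n1)N(Cc1ccccc1)C(C(=O)O)N2` — > 64000 nM
compound 2, `CCCSc1nc(Cl)c2c(n1)N(Cc1cccs1)C(C(=O)N1CCN(C)CC1)N2` — 62300 nM

Among the compounds with values here, in a functional assay on MGC-803 cells (Homo sapiens) for antiproliferative activity, read by MTT assay, with a stated time of 72 h (a higher number here means a weaker inhibitor, a lower number a stronger inhibitor), compound 2 gives 62300 nM, the only plain number in this small set. Compound 1 returns > 64000 nM, which is a limit of the assay rather than a number (the limit of > 64000 nM in this assay, at which 1 of the 2 values shown sits). Compound 2 therefore stands alone as the single measured point, and that point marks a weak inhibitor.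

Compound 3, `CCCSc1nc(Cl)c2c(n1)N(CC1CCCCC1)C(C(=O)N1CCN(C)CC1)N2`, differs from compound 2 in one place: cyclohexyl in place of thiophen-2-yl on a saturated chain carbon bound to a nitrogen on an aromatic ring in a ring. Within the data shown here, no measured pair shows this change, so no size of step can be read from the data. The expected step is a 1.1-fold lower number from compound 2 to compound 3 (0.05 log units; within the scatter), that is, none beyond the usual scatter, and there is a real chance the assay again reports only a limit. Compound 3 is estimated at 55000 nM, within a range from 20000 nM to 150000 nM.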

Compound 3, half-maximal inhibitory concentration: > 64000 nM
Compound 3: a limit, no number (the forecaster's own chance of this, stated with the estimate: 45%); at least 1.1-fold (0.06 log units) between middle value and limit.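

In this assay, putting cyclohexyl in place of thiophen-2-yl on a saturated chain carbon bound to a nitrogen on an aromatic ring in a ring gives an at least 1.0-fold higher number from compound 2 to compound 3 (0.01 log units; that floor lies within the scatter). The result for compound 3 is a limit and not a number, so this step has a floor but no known size. It does show that exchanging the five-membered aromatic ring for a six-membered carbon ring did not produce a stronger inhibitor at this position, and compound 2 remains the only plain number in the set: the limit of > 64000 nM in this assay, at which 2 of the 3 values shown sit.

The compounds shown leave open whether any group at this position can bring the number well under that limit. A pyridine ring or a group carrying an amine in place of thiophen-2-yl would be a direct test of this.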